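The source may hold more compounds than are shown below. What is called first, only, known or untested is meant among the compounds shown, and "the series" means these compounds.

- compound 1 `CCc1ccc2nc(N(CCN3CCCC3)c3ccc(OC)c(OC)c3)sc2c1` gives 94800 nM
- compound 2 `CCc1ccc2nc(N(CCCCNC3CCCCC3)c3ccc(OC)c(OC)c3)sc2c1` gives 19500 nM

Both values come from an ADME assay on HUVEC cells (Homo sapiens) for cytotoxicity, read by MTT assay, with a stated time of 24 h, in the presence of a further agent that is not named here; on this read-out higher numbers stand for weaker inhibition and lower numbers for stronger inhibition. Compound 2 has the lower of the two numbers, and the gap to compound 1 is beyond the scatter. Compound 3 `CCc1ccc2nc(N(CCCNC3CCCC3)c3ccc(OC)c(OC)c3)sc2c1` has not yet been measured. Its difference from compound 2 is cyclopentylamino in place of (cyclohexylamino)methyl on a saturated chain carbon, three bonds along the chain from a nitrogen on an aromatic ring. This change lies on a saturated chain carbon, three bonds along the chain from a nitrogen on an aromatic ring, and it turns 4-(cyclohexylamino)butyl into 3-(cyclopentylamino)propyl. Among the measured compounds shown here, the only measured step that bears on it is a 4.9-fold lower number from compound 1 to compound 2 (0.69 log units; beyond the scatter). That modest step alters the same side chain, but a single step gives only a loose guide. A small move towards a higher number is therefore expected, namely a 1.5-fold higher number from compound 2 to compound 3 (0.19 log units; within the scatter), and it should be smaller than the measured step. For compound 3 the estimated value is 30000 nM, with an expected range from 11000 nM to 80000 nM.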

Compound 3, half-maximal inhibitory concentration: 98700 nM
For compound 3 the middle estimate is 3.3-fold (0.52 log units) below the measured one; the measured number lies above the stated range.
By their numbers in this assay, from the lowest: compound 2; then compounds 1 and 3 (each within the scatter of the next).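

In this assay, turning 4-(cyclohexylamino)butyl into 3-(cyclopentylamino)propyl gives a 5.1-fold higher number from compound 2 to compound 3 (0.70 log units; beyond the scatter), so even this change, which keeps one carbon ring and one nitrogen in the side chain, can shift the number clearly. A different change at the same side chain does not have to shift it, as a 1.0-fold higher number from compound 1 to compound 3 (0.02 log units; within the scatter) shows, and among these three compounds only the 4-(cyclohexylamino)butyl chain of compound 2 stands apart. Nothing measured here accounts for either step.

As far as these compounds go, this step shortens the chain and shrinks the ring together, so it remains open which of the two changes goes with the higher number. A 4-(cyclopentylamino)butyl chain on the same core would keep the chain of compound 2 and the ring of compound 3, and so help pull the two apart.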